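Dropping the methoxy: from compound 2 to compound 4

This account rests on a few compounds, and the source may have more. Where it says the series, first, only, none or still open, it means among the compounds named here.

Measured compounds:
compound 1 `[SeH]c1nc(NCc2ccccc2)c2cccnc2n1` gives > 100000 nM
compound 2 `COc1ccc(CNc2nc(SC)nc3ncccc23)cc1` gives > 100000 nM
compound 3 `COc1ccc(CNc2nc(SC)nc3ccccc23)cc1` gives > 100000 nM

All three were tested in a functional assay on HT-29 cells (Homo sapiens) for cytotoxicity, read by MTT assay, with a stated time of 72 h; on this read-out higher numbers stand for lower toxicity in this test and lower numbers for higher toxicity in this test. For compound 2 the value is a limit of the test, not a number. All three values sit at the limit of > 100000 nM in this assay, at which 3 of the 3 values shown sit, so compound 2 cannot be ranked against compound 1 or compound 3.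

Compound 4 `CSc1nc(NCc2ccccc2)c2cccnc2n1` differs from compound 2 by hydrogen in place of methoxy on an aromatic carbon. Among the compounds with values here, no step between measured compounds is available, so the size of this change in this assay cannot be read from the data; no shift beyond the scatter is expected. Compound 4 is therefore expected to give 100000 nM, within 30000 nM to 300000 nM. The expected step is a number no higher from compound 2 to compound 4 (the limit leaves the size open).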

Compound 4, concentration lethal to 50% of the cells: > 100000 nM
Compound 4: a limit, no number; the forecaster's own chance of this, stated with the estimate: 80%; the middle value lies on the limit itself.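

Compound 4 gives only a limit, as do compound 1 and compound 2, so neither step to compound 4 can be read: the limit of > 100000 nM in this assay, at which 4 of the 4 values shown sit.

The compounds shown leave open how far either change shifts toxicity, as none gives an actual number.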